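N-Methylation of the oxazole carboxamide in compound 1

This account rests on a few compounds, and the source may have more. Where it says the series, first, only, none or still open, it means among the compounds named here.

Compound 1 `NC(=O)c1cnc(C(=O)CCc2ccc(Oc3ccccc3)cc2)o1` stands with the highest number of the three measured: in an assay for inhibition of Fatty-acid amide hydrolase 1 (Rattus norvegicus) (on this read-out higher numbers stand for weaker inhibition and lower numbers for stronger inhibition), compound 1 gives 6.6 nM. Compound 2 `CS(=O)(=O)c1cnc(C(=O)CCc2ccc(-c3ccccc3)cc2)o1` gives 1.2 nM in this assay, and compound 3 `NC(=O)c1ccc(-c2cnc(C(=O)CCc3ccc(-c4ccccc4)cc3)o2)nc1` gives 1.3 nM; both lie beyond the scatter below compound 1. Within the data shown here, the one single-point step measured so far, a 1.1-fold higher number from compound 2 to compound 3 (0.03 log units; within the scatter), concerns the substituent on the core and leaves the carbonyl chain untouched.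

Compound 4 `CNC(=O)c1cnc(C(=O)CCc2ccc(Oc3ccccc3)cc2)o1` differs from compound 1 only by methyl in place of hydrogen on an amide-type nitrogen. Among the measured compounds shown here, no measured step touches the amide nitrogen, so nothing shows what this change does; the step from compound 2 to compound 3 exchanges the whole group on the core rather than a hydrogen on it and is not a guide here. For the measured compounds named here, with no direct precedent, the expectation is a small change, leaning toward a somewhat higher number, close to the scatter: the expected step is a 1.5-fold higher number from compound 1 to compound 4 (0.18 log units; within the scatter). Compound 4 is therefore estimated at 10 nM in this assay, with a range from 3 nM to 40 nM.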

Compound 4, inhibition constant: 11 nM
Estimate against measurement, compound 4: 1.1-fold (0.04 log units) below; low and high end bracket the measured number.
By their numbers in this assay, from the lowest: compounds 2 and 3 (each within the scatter of the next); then compounds 1 and 4 (each within the scatter of the next).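

In this assay, among these compounds, the only measured change on the amide-type nitrogen, methyl in place of hydrogen, is a 1.7-fold higher number from compound 1 to compound 4 (0.22 log units; within the scatter). Carbamoyl and methylcarbamoyl therefore cannot be told apart on this read-out: with the rest of compound 1 held fixed, this nitrogen accepts one methyl, and losing that amide hydrogen does not move the number beyond the scatter. No data on why the two numbers sit together are on hand.

Still open, going by these compounds, is whether the same holds for a longer chain such as ethyl, for dimethylcarbamoyl, where no amide hydrogen remains, or for a carboxylic acid in place of the carbamoyl. Also open, on these data alone, is whether methyl on the amide nitrogen of compound 3 would read the same, as that compound differs from compound 1 in more than one place.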